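This account rests on a few compounds, and the source may have more. Where it says the series, first, only, none or still open, it means among the compounds named here.

Working notes on the series.

The common core is carried by compound 1 `CNc1nc2ccccc2c(=O)o1`, whose lipophilicity was read in a physicochemical assay for lipophilicity (a higher number here means a more lipophilic compound, a lower number a more polar compound), where compound 1 gives 1.7. Two further measured members sit around it. Compound 3 `Cc1ccc2nc(C)oc(=O)c2c1` gives 1.8 in this assay, a value that lies within the scatter of the measurement of compound 1, so the two are not separated by this method. Compound 2 `CCc1ccc2c(=O)oc(NC(C)C)nc2c1` gives 3.2 in this assay, which stands beyond the scatter above compound 1 and marks the upper end of what has been measured so far. For the measured compounds named here, no pair of the three measured compounds differs in a single place, so no step between them can be traced to one structural change.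

Compound 4 `CCCCNc1nc2ccccc2c(=O)o1` is not yet measured. Relative to compound 1 the change is propyl in place of hydrogen on a saturated chain carbon bound to a nitrogen on an aromatic ring. With three carbon atoms entering and no donor or acceptor added, a rise in this assay beyond the scatter is expected, towards the region occupied by compound 2 with 3.2. The expected step from compound 1 to compound 4 is a number 1.40 log units higher from compound 1 to compound 4 (beyond the scatter). Compound 4 is accordingly estimated at 3.1, with a range from 2.7 to 3.5.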

Compound 4, distribution coefficient: 3.1
Compound 4: middle estimate and measured number agree at the digits printed; the range from low to high includes it.
By their numbers in this assay, from the lowest: compounds 1 and 3 (each within the scatter of the next); then compounds 4 and 2 (each within the scatter of the next).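

Propyl in place of hydrogen on a saturated chain carbon bound to a nitrogen on an aromatic ring, read equally as methylamino to butylamino, gives the first step in the series that can be traced to one structural change: in this assay the read-out is a number 1.40 log units higher from compound 1 to compound 4 (beyond the scatter) and the shared core stays untouched. This position is thus shown to respond to the change, with no hydrogen-bond donor or acceptor entering alongside the propyl, which could not be read from compound 2 or compound 3, as neither differs from compound 1 in a single place. No independent evidence in hand bears on the origin of this step.

From the compounds shown here alone, a single pair gives one chain length on this nitrogen, so it remains open whether a longer chain such as hexyl would extend the step or whether the number levels off after butyl. Also open, going by these compounds, is how the same position would respond to a butyl chain ending in a carboxylic acid or an amine, or to a cyclic group such as cyclohexyl.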